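Swapping fluoro for chloro on a shared core

The compounds below may be only part of what the source reports. "The series", "measured", "known", "first", "only" and "open" are said of these compounds alone.

Compound 1, `O=C(Nc1nc2ccc(Cl)cc2s1)c1cn(-c2ccccc2)nc1-c1ccccc1`: 4980 nM
Compound 2, `O=C(Nc1nc2ccc(F)cc2s1)c1cn(-c2ccccc2)nc1-c1ccc(F)cc1`: 12500 nM

In a functional assay on U-87MG ATCC cells for cytotoxicity against U-87 MG (Homo sapiens), read by MTT assay, with a stated time of 72 h (on this read-out lower numbers stand for stronger inhibition and higher numbers for weaker inhibition), compound 1 gives 4980 nM, while compound 2 gives 12500 nM. Compound 2 therefore has the higher of the two numbers, and the gap to compound 1 lies beyond the usual scatter. Compounds 1 and 2 differ in two places at once, so their values are reported side by side without tracing a single change between them.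

Compound 3, `O=C(Nc1nc2ccc(Cl)cc2s1)c1cn(-c2ccccc2)nc1-c1ccc(F)cc1`, has not yet been measured. It differs from compound 2 by chloro in place of fluoro on an aromatic carbon; in other words, 6-fluoro-1,3-benzothiazol-2-yl becomes 6-chloro-1,3-benzothiazol-2-yl, so compound 3 carries the same chloro as compound 1 while keeping the fluoro-bearing phenyl of compound 2. Since compound 1 with that chloro gives 4980 nM, a modest move toward a lower number is expected, an estimated step of a 1.8-fold lower number from compound 2 to compound 3 (0.25 log units; within the scatter). Compound 3 is estimated at 7000 nM, within a range from 3000 nM to 16000 nM.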

Compound 3, half-maximal inhibitory concentration: 6770 nM
Compound 3: the middle estimate sits 1.0-fold (0.01 log units) above what was measured, and the stated range covers the measured number.
By their numbers in this assay, from the lowest: compounds 1, 3 and 2 (each within the scatter of the next, the first and the last beyond it).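

In this assay, the exchange of 6-fluoro-1,3-benzothiazol-2-yl for 6-chloro-1,3-benzothiazol-2-yl can now be read on its own, and chloro in place of fluoro gives a 1.8-fold lower number from compound 2 to compound 3 (0.27 log units; within the scatter) on the shared core. The second change, fluoro in place of hydrogen on an aromatic carbon, can also be read on its own as a 1.4-fold higher number from compound 1 to compound 3 (0.13 log units; within the scatter), so the two changes that separate compound 1 and compound 2 can be taken one at a time, and neither alone clears the scatter. No measurement shown here explains these steps.

Only two halogens appear at this position, so the compounds shown leave open how a methoxy group, an amine or a carboxylic acid would read there. They also leave open how a hydrogen there would compare with chloro and fluoro.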